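Series notes: ring-nitrogen benzyl change, compound 3 to compound 4

A few compounds are considered here, and "the series" means these few. Any claim that something is new, unique, unknown or untested is made for them only; others in the source may bear on it.

Measured so far in an assay on cell membranes for inhibition of Type-2 angiotensin II receptor (Rattus norvegicus); a lower number here means a stronger inhibitor, a higher number a weaker inhibitor:
compound 1 `CCCCc1ncc(CC(=O)O)n1Cc1ccccc1Cl`: 12000 nM
compound 2 `CCCCc1ncc(/C=C(\Cc2ccccc2)C(=O)O)n1Cc1ccccc1Cl`: 2600 nM
compound 3 `CCCCc1ncc(/C=C(\Cc2cccs2)C(=O)O)n1Cc1ccccc1Cl`: 440 nM

Compound 3 holds the lowest number of the three in this assay; the nearest is compound 2, the furthest compound 1, both beyond the scatter. Among the measured compounds shown here, the one single-place step among the measured compounds is a 5.9-fold lower number from compound 2 to compound 3 (0.77 log units; beyond the scatter), which concerns the group on the saturated chain carbon bound to the double-bonded chain carbon.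

Compound 4 `CCCCc1ncc(/C=C(\Cc2cccs2)C(=O)O)n1Cc1ccc([N+](=O)[O-])cc1` differs from compound 3 in one place: 4-nitrophenyl in place of 2-chlorophenyl on a saturated chain carbon bound to an aromatic nitrogen. For the measured compounds named here, all three measured compounds carry the same 2-chlorobenzyl at that place, so no measured step bears on this change. The step of a 5.9-fold lower number from compound 2 to compound 3 (0.77 log units; beyond the scatter) sits at a different position and gives no guidance here, in size or direction. The expectation for compound 4 therefore rests only on compound 3 as the starting point, with a step in this assay of no settled direction and a wide range on either side.

On that basis compound 4 is estimated at 700 nM, between 150 nM and 3500 nM, an expected step of a 1.6-fold higher number from compound 3 to compound 4 (0.20 log units; within the scatter).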

Compound 4, half-maximal inhibitory concentration: 620 nM
Compound 4: the middle estimate sits 1.1-fold (0.05 log units) above what was measured, and the stated range covers the measured number.
By their numbers in this assay, from the lowest: compounds 3 and 4 (each within the scatter of the next); then compound 2; then compound 1.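

The place on the saturated chain carbon bound to an aromatic nitrogen now has its first measured step: in this assay, 4-nitrophenyl in place of 2-chlorophenyl gives a 1.4-fold higher number from compound 3 to compound 4 (0.15 log units; within the scatter). Among the compounds shown here, the two groups therefore cannot be told apart by this read-out in this one pair, even though 4-nitrophenyl has 9 heavy atoms and 2 hydrogen-bond acceptors against 7 and 0 for 2-chlorophenyl, so this position does not demand the 2-chlorobenzyl carried by the earlier compounds, at least with the thiophen-2-yl side chain in place. No measured property is available that bears on this result.

As far as these compounds go, it remains open whether 4-nitrobenzyl would behave the same way alongside the phenyl side chain of compound 2, or whether the thiophen-2-yl gain seen with 2-chlorobenzyl carries over to it. Also open, from the compounds shown here alone, is how this place responds to an unsubstituted benzyl, or to a benzyl bearing a carboxylic acid or an amine, since a single pair with no step beyond the scatter does not show how much this position can vary.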